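Removing one trifluoromethyl from a diaryl urea growth inhibitor

The source may hold more compounds than are shown below. What is called first, only, known or untested is meant among the compounds shown, and "the series" means these compounds.

Two compounds share a urea-linked core and differ only in the substituents on the outer aromatic ring. Compound 1 `COc1cc(Cl)cc(-c2nn(-c3cccc(NC(=O)Nc4ccc(Cl)c(C(F)(F)F)c4)c3)cc2-c2ccncc2)c1` carries a chlorine and a trifluoromethyl there; compound 2 `COc1cc(Cl)cc(-c2nn(-c3cccc(NC(=O)Nc4cc(C(F)(F)F)cc(C(F)(F)F)c4)c3)cc2-c2ccncc2)c1` carries two trifluoromethyl groups. In a functional assay on A549 cells (Homo sapiens) for inhibition, read by sulforhodamine B assay, with a stated time of 48 h, tested at 1 uM (a higher number here means a weaker effect of the compound at the concentration tested, a lower number a stronger effect), compound 1 gives 40%, while compound 2 gives 15%, the lower of the two numbers and a difference beyond the usual scatter, so compound 2 is the stronger of the pair.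

Compound 3 `COc1cc(Cl)cc(-c2nn(-c3cccc(NC(=O)Nc4cccc(C(F)(F)F)c4)c3)cc2-c2ccncc2)c1` takes the next step: one trifluoromethyl of compound 2 leaves and a hydrogen enters (hydrogen in place of trifluoromethyl on an aromatic carbon). Within the data shown here, no measured pair shows this change, so the step in this assay can only be anticipated. Since compound 2 sits at 15% and the less substituted compound 1 sits at 40%, losing a group is expected to raise the number, giving a number 30 percentage points higher from compound 2 to compound 3 (beyond the scatter). Compound 3 is therefore estimated at 45%, within 20% to 75%.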

Compound 3, a percentage reported as activity, at one concentration (the size of the read-out at that concentration, not a potency): 43%
Compound 3: the middle estimate sits 2 percentage points above what was measured; the range from low to high includes it.
By their numbers in this assay, from the lowest: compound 2; then compounds 1 and 3 (each within the scatter of the next).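

In this assay, among these compounds, the step of a number 28 percentage points higher from compound 2 to compound 3 (beyond the scatter) is the first direct reading of this change: replacing one trifluoromethyl with hydrogen, at a place meta to the remaining trifluoromethyl group, weakens the effect by more than the scatter. The other step, a number 3 percentage points higher from compound 1 to compound 3 (within the scatter), stays within the scatter, so hydrogen in place of the chloro of compound 1 makes no measurable difference here, unlike the loss of the trifluoromethyl from compound 2. Nothing available explains why these two replacements on the same outer ring read so differently.

From the compounds shown here alone, whether a different group at the place of the lost trifluoromethyl, such as an amine or a carboxylic acid, could match compound 2 remains open. These are also readings at one concentration, so they leave the potencies of the compounds open.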